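Methoxy to bromo on the shared core

The source may report more compounds than this note shows. Statements on the series, on what has been measured and on what is new or still open speak of the compounds shown alone.

Compound 2 `CCCCCn1c(N)nc2c(OC)cccc21` has been measured in an assay on HEK293 cells for agonist activity at Toll-like receptor 8 (Homo sapiens), read by reporter gene assay; on this read-out higher numbers stand for an effect only at larger amounts of compound and lower numbers for an effect already at smaller amounts. In this assay compound 2 gives 3740 nM. For the measured compounds named here, the only other measured compound, compound 1 `CCCCCCn1c(N)nc2ccccc21`, gives 3960 nM in this assay, and the two numbers lie within the usual scatter of each other, so compound 2 stands level with compound 1 on the numbers so far. Compound 3 `CCCCCn1c(N)nc2c(Br)cccc21` is not yet measured. It differs from compound 2 by bromo in place of methoxy on an aromatic carbon. Going by the values given here, no step of this kind has been measured, so the expected step from compound 2 to compound 3 is a 1.2-fold lower number from compound 2 to compound 3 (0.07 log units; within the scatter), that is, none beyond the scatter in either direction. Compound 3 is therefore expected to give about 3200 nM in this assay, within a range from 1000 nM to 10000 nM.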

Compound 3, half-maximal effective concentration: "not active" (no number reported)
No number was reported for compound 3, and the estimate cannot be compared.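

For the compounds shown here, compound 3 carries no reported number, so no step from compound 2 to compound 3 can be read. On these data alone, how far bromo in place of methoxy shifts the read-out stays open. No evidence shown bears on this result.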